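The compounds below may be only part of what the source reports. "The series", "measured", "known", "first", "only" and "open" are said of these compounds alone.

Of the compounds shown here, two built on one shared core have been measured in an assay on isolated protein (adrenal medulla) for inhibition of Dopamine beta-hydroxylase (Bos taurus); on this read-out higher numbers stand for weaker inhibition and lower numbers for stronger inhibition. Compound 1 `Nc1ncn(Cc2cccc(C(F)(F)F)c2)c2ncnc1-2` gives 20 ug/mL in this assay. Compound 2 `CCn1cnc(N)c2ncnc1-2` stands at a limit of this assay, > 200 ug/mL, as the limit of > 200 ug/mL in this assay, at which 1 of the 2 values shown sits, records. Compound 3 `CCCn1cnc(N)c2ncnc1-2` differs from compound 2 in one place: methyl in place of hydrogen on a saturated chain carbon, two bonds along the chain from an aromatic nitrogen. Within the data shown here, no measured pair shows this kind of change, and the comparison of compound 1 with compound 2 concerns a different group. Compound 3 is expected to shift by a number no higher from compound 2 to compound 3 (the limit leaves the size open), a step not beyond the usual scatter. Compound 3 is therefore estimated at 200 ug/mL, between 60 ug/mL and 600 ug/mL.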

Compound 3, half-maximal inhibitory concentration: 200 ug/mL
Compound 3: the middle estimate sits on the measured number at the digits printed; the measured number falls inside the stated range.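

Compound 2 stands at a limit in this assay, > 200 ug/mL, and this is a limit and not a number. Compound 3, with propyl in place of ethyl, gives this position its first actual number, 200 ug/mL, so methyl in place of hydrogen on this chain carbon reads as a number no higher from compound 2 to compound 3 (the limit leaves the size open). The size of that step cannot be read: the limit of > 200 ug/mL in this assay, at which 1 of the 3 values shown sits.

The compounds shown leave open what a longer chain, such as butyl, would do. They also leave open whether an amine or a carboxylic acid in place of this methyl would move the value.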